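Removing the fluoro from the aryl group of compound 2

The source may report more compounds than this note shows. Statements on the series, on what has been measured and on what is new or still open speak of the compounds shown alone.

Measured compounds:
compound 1 `COc1ccc(-n2nc(C(=O)Nc3ccc(Oc4ccncc4-c4cccnc4)c(F)c3)c3ccccc3c2=O)cc1` with 740 nM
compound 2 `O=C(Nc1ccc(Oc2ccncc2-c2cccnc2)c(F)c1)c1nn(-c2cccc(F)c2)c(=O)c2ccccc12` with 27 nM

In a functional assay on MKN-45 cells (Homo sapiens) for cytotoxicity, read by MTT assay, with a stated time of 72 h (on this read-out lower numbers stand for stronger inhibition and higher numbers for weaker inhibition), compound 1 gives 740 nM, and compound 2 gives 27 nM. Among the compounds with values here, compound 2 thus stands lowest of the two numbers; the one step to it, a 27-fold lower number from compound 1 to compound 2 (1.44 log units; beyond the scatter), was large and came from a change on the aromatic nitrogen of the shared core. Compound 3 `O=C(Nc1ccc(Oc2ccncc2-c2cccnc2)c(F)c1)c1nn(-c2ccccc2)c(=O)c2ccccc12` differs from compound 2 by hydrogen in place of fluoro on an aromatic carbon. Within the data shown here, no measured step trades a fluoro for hydrogen; only the large step from compound 1 to compound 2 bears on the aryl group at all, and it changed a different substituent pattern. The change is a single heavy atom, so compound 3 is expected to give a number not far from compound 2, a 2.0-fold higher number from compound 2 to compound 3 (0.31 log units; beyond the scatter), within or a little beyond the scatter. The estimate for compound 3 in this assay is 55 nM, ranging from 20 nM to 200 nM.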

Compound 3, half-maximal inhibitory concentration: 90 nM
The estimate for compound 3 lay 1.6-fold (0.21 log units) below the measured number, within the range that was stated.
By their numbers in this assay, from the lowest: compound 2; then compound 3; then compound 1.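

In this assay the 3-fluorophenyl group proves better than plain phenyl, since taking away the fluoro alone gives a 3.3-fold higher number from compound 2 to compound 3 (0.52 log units; beyond the scatter) and so a real loss from one atom. The unsubstituted phenyl also separates the two halves of the earlier large change: losing the methoxy alone gives an 8.2-fold lower number from compound 1 to compound 3 (0.91 log units; beyond the scatter), and this is the larger part of that change. Adding the fluoro to the phenyl accounts for the rest, so on this aryl group compound 3 sits between a methoxy that goes with a higher number and a fluoro that goes with a lower one. On these data alone, how a chloro, a methyl or an amine on that same carbon would compare stays open. Nothing shown gives a reason for either step.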